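The source may report more compounds than this note shows. Statements on the series, on what has been measured and on what is new or still open speak of the compounds shown alone.

Measured so far in a functional assay on the whole organism (Tail, strain ICR) with Mus musculus as the target, in the tail flick test, with a stated time of 60 min, at a dose of 25 umol/kg by the oral route; on this read-out higher numbers stand for a stronger effect at the one dose given and lower numbers for a weaker effect:
compound 1 `O=C(CN(c1nc(Cl)nc2[nH]cnc12)C1CC1)NCC(=O)OCc1ccccc1` — 41.9%
compound 2 `O=C(O)CNC(=O)CN(c1nc(Cl)nc2[nH]cnc12)C1CC1` — 38.9%
compound 3 `C[C@@H](O)[C@H](NC(=O)CN(c1ncnc2c1ncn2C1CCCCO1)C1CC1)C(=O)OCc1ccccc1` — 28.4%

Compound 2 stands within the usual scatter of compound 1 and beyond the scatter above compound 3, which carries a different core and a different amino-acid portion, so no single-step comparison exists for that pair. Among the compounds with values here, the one step among the measured compounds, a number 3 percentage points lower from compound 1 to compound 2 (within the scatter), concerns the ester end only and is within the scatter.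

Compound 4 `CC(C)C[C@H](NC(=O)CN(c1nc(Cl)nc2[nH]cnc12)C1CC1)C(=O)O` differs from compound 2 by isobutyl in place of hydrogen on a saturated chain carbon bound to an amide-type nitrogen and a carbonyl carbon. Within the data shown here, no measured step touches this position: the series so far varies the ester end and the core, not the saturated chain carbon bound to the amide-type nitrogen and the carbonyl carbon. Compound 3 carries a substituted chain carbon of a different kind together with a different core, so it cannot be read as a guide here. With nothing bearing directly on the change, the step of a number 0.9 percentage points lower from compound 2 to compound 4 (within the scatter) is expected to stay near zero and within the scatter. For compound 4 the estimate in this assay is 38%, ranging from 23% to 53%.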

Compound 4, a percentage reported as activity, at one dose (the size of the read-out at that dose, not a potency): 36.4%
For compound 4 the middle estimate is 1.6 percentage points above the measured one, within the range that was stated.
By their numbers in this assay, from the lowest: compounds 3, 4, 2 and 1 (each within the scatter of the next, the first and the last beyond it).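

In this assay, isobutyl in place of hydrogen on a saturated chain carbon bound to an amide-type nitrogen and a carbonyl carbon gives a number 2.5 percentage points lower from compound 2 to compound 4 (within the scatter). Within the data shown here, this is the first reading at this position, and it shows that isobutyl can stand there, on the shared core and with the free carboxylic acid end kept, without a step beyond the scatter at the one dose given. No available evidence accounts for this result.

Open at this carbon is whether a longer chain, a phenyl ring or an amine would also stay within the scatter of compound 2. Also open, going by these compounds, is whether isobutyl would stay within the scatter on the benzyl ester of compound 1, since a single dose gives no potency for either comparison.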